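Hydroxyphenyl for methanesulfonamidophenyl on the biphenyl-type ether

This account rests on a few compounds, and the source may have more. Where it says the series, first, only, none or still open, it means among the compounds named here.

Measured compounds:
compound 1 `CS(=O)(=O)Nc1cccc(-c2ccc(COC3CC[C@H](N4CCCCCC4)[C@H]3OC/C=C\CCC(=O)O)cc2)c1` 12.6 nM
compound 2 `O=C(O)CC/C=C\CO[C@@H]1[C@@H](OCc2ccc(-c3ccccc3)cc2)CC[C@@H]1N1CCCCC1` 100 nM

Within the data shown here, compound 1 stands at the lowest number of the two measured in a functional assay on blood for antagonist activity at thromboxane A2 receptor (Homo sapiens); a higher number here means weaker binding, a lower number tighter binding; compound 2 sits higher, and the gap between the two is beyond the usual scatter, though the two structures differ in more than one place and no single step is drawn between them. Compound 3 `O=C(O)CC/C=C\CO[C@H]1C(OCc2ccc(-c3ccccc3O)cc2)CC[C@@H]1N1CCCCCC1` has not yet been measured. It is related to compound 1 by one change: 2-hydroxyphenyl in place of 3-(methanesulfonamido)phenyl on an aromatic carbon. Compound 2, which carries no group at all at that position, gives a higher number than compound 1, so the step from compound 1 to compound 3 is expected to move upward, by a 3.2-fold higher number from compound 1 to compound 3 (0.50 log units; beyond the scatter), beyond the scatter but less than the gap to compound 2. Compound 3 is therefore estimated at 40 nM in this assay, with a range of 12 nM to 150 nM.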

Compound 3, dissociation constant: 15.9 nM
Compound 3: middle estimate off by 2.5-fold (0.40 log units), on the high side; measured number inside the range.
By their numbers in this assay, from the lowest: compounds 1 and 3 (each within the scatter of the next); then compound 2.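

In this assay, among these compounds, replacing the 3-(methanesulfonamido)phenyl of compound 1 with the 2-hydroxyphenyl of compound 3 gives a 1.3-fold higher number from compound 1 to compound 3 (0.10 log units; within the scatter), the first single-place comparison at this aromatic carbon, para to a large group. The methanesulfonamide, with its 11 heavy atoms, is therefore not needed to hold the number at this level, since a 2-hydroxyphenyl of 7 heavy atoms serves within the scatter on the same core. No measurement at hand explains why the two groups match.

Because the group and its place on the ring change together, this pair cannot show which of the two matters, or how each would act alone. On these data alone, whether an amine or a carboxylic acid on that outer phenyl ring would match the hydroxyl also remains open.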